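Swapping Cyclohexyl for 2-Hydroxyethyl on an Amide Nitrogen

A few compounds are considered here, and "the series" means these few. Any claim that something is new, unique, unknown or untested is made for them only; others in the source may bear on it.

Compound 1, `COc1cccc2cc(C(=O)NC3CCCCC3)c(=N)oc12`, gives 40% in an assay on CHO cells for displacement of a labelled ligand from adenosine receptor A1 (Homo sapiens), read by scintillation counting, with a stated time of 60 min, tested at 10 uM; on this read-out lower numbers stand for less inhibition and higher numbers for more inhibition at the one concentration tested (going by the name of the read-out).
Compound 2, `N=c1oc2ccc(Br)cc2cc1C(=O)NCCO`, gives 26%.
Compound 3, `N=c1oc2ccc(Br)cc2cc1C(=O)NC1CCCC1`, gives 17%.

Among these three numbers compound 1 stands highest: the nearest, compound 2, lies a gap beyond the scatter below it, and compound 3 lies further below still, also beyond the scatter.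

Compound 4, `COc1cccc2cc(C(=O)NCCO)c(=N)oc12`, has not yet been measured in this assay. It differs from compound 1 in one place: 2-hydroxyethyl in place of cyclohexyl on an amide-type nitrogen.

Among the measured compounds shown here, one measured step bears on this change. Between compound 2 and compound 3 the 2-hydroxyethyl was traded for a cyclopentyl on the same kind of nitrogen, and the result was a number 9 percentage points lower from compound 2 to compound 3 (within the scatter), a step that stays within the scatter. The present change runs in the opposite direction, from a ring to the 2-hydroxyethyl, though the rest of compound 1 differs from compound 2 and compound 3, so the comparison is only a guide. A step of no more than the scatter is therefore expected, perhaps a small rise.

Compound 4 is expected to give about 45%, within a range from 27% to 63%. The expected step is a number 5 percentage points higher from compound 1 to compound 4 (within the scatter).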

Compound 4, a percentage reported as inhibition, at one concentration (the size of the read-out at that concentration, not a potency): 47%
For compound 4 the middle estimate is 2 percentage points below the measured one, and the stated range covers the measured number.
By their numbers in this assay, from the lowest: compounds 3 and 2 (each within the scatter of the next); then compounds 1 and 4 (each within the scatter of the next).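

On the core of compound 1, putting 2-hydroxyethyl in place of cyclohexyl on the amide-type nitrogen gives a number 7 percentage points higher from compound 1 to compound 4 (within the scatter) in this assay, so a carbon ring and an open chain ending in a hydroxyl cannot be told apart here. The earlier step, a number 9 percentage points lower from compound 2 to compound 3 (within the scatter), compared 2-hydroxyethyl with a different ring on another core, so the two pairs now agree that swapping a ring for this chain stays within the scatter, on both cores shown. Nothing measured here says why the two groups read alike.

As far as these compounds go, whether an amine, a carboxylic acid or a longer chain on this nitrogen would also stay within the scatter remains open. Also open is whether the effects of these compounds, each measured at a single concentration, would read alike at other concentrations.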